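The compounds below may be only part of what the source reports. "The series", "measured", "known", "first", "only" and "open" are said of these compounds alone.

Working notes on the series. Compound 1 `[SeH]c1nc(NCc2ccccc2)c2cccnc2n1` is measured in a functional assay on CCRF-CEM cells (Homo sapiens) for cytotoxicity, read by MTT assay, with a stated time of 72 h (a higher number here means a weaker inhibitor of growth, a lower number a stronger inhibitor of growth), at 68900 nM. Compound 2 `CSc1nc(NCCCCCO)c2cccnc2n1` gives only a limit of this assay, > 100000 nM, and that limit is all that is known for compound 2 here, as stated by the limit of > 100000 nM in this assay, at which 1 of the 2 values shown sits. Compound 3 `CSc1nc(NCc2ccccc2)c2cccnc2n1` differs from compound 2 by phenyl in place of 4-hydroxybutyl on a saturated chain carbon bound to a nitrogen on an aromatic ring. Among the measured compounds shown here, no step between measured compounds exists, so the size of this move is not fixed by data, but it is expected to be modest and toward stronger inhibition of growth. Compound 3 is estimated at 80000 nM with a range of 35000 nM to 180000 nM. The expected step is an at least 1.2-fold lower number from compound 2 to compound 3 (0.09 log units; that floor lies within the scatter).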

Compound 3, concentration for total growth inhibition: 98600 nM
Beside the measured number, compound 3's estimate is 1.2-fold (0.09 log units) below it; the measured number falls inside the stated range.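

In this assay, among the compounds shown here, the carbon-and-sulfur group in place of the selenium atom, on an aromatic carbon, gives a 1.4-fold higher number from compound 1 to compound 3 (0.16 log units; within the scatter) as the first readable step at this place, and that step does not go beyond the scatter. Phenyl in place of 4-hydroxybutyl on a saturated chain carbon bound to a nitrogen on an aromatic ring gives an at least 1.0-fold lower number from compound 2 to compound 3 (0.00 log units; that floor lies within the scatter) as the only reading there. Compound 2 is held only by a limit of the assay, so this step has no fixed size: the limit of > 100000 nM in this assay, at which 1 of the 3 values shown sits.

Open, on these data alone, is how an amine or a carboxylic acid in place of phenyl would read in this assay. Also open, as far as these compounds go, is whether a longer chain on that carbon would read differently from 4-hydroxybutyl.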